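Acetyl in Place of Hydrogen: Cytotoxicity Expected for Compound 4

This account rests on a few compounds, and the source may have more. Where it says the series, first, only, none or still open, it means among the compounds named here.

Compound 1 `CCOC(=O)c1c(-c2ccccc2)[nH]c2cc(OC)ccc2c1=O`: > 21500 nM in an ADME assay on Raji cells (Homo sapiens) for cytotoxicity, read by luminescence, with a stated time of 72 h (a higher number here means that more compound is needed for the effect, a lower number that less compound is needed), a limit of the assay.
Compound 2 `CCOC(=O)c1c(-c2cccc(OCc3ccccc3)c2)[nH]c2cc(OC)ccc2c1=O`: > 21500 nM, a limit.
Compound 3 `CCOC(=O)c1c(-c2cccc(C(F)(F)F)c2)[nH]c2cc(OC)ccc2c1=O`: > 21500 nM, a limit.

Compound 1 stands only at a limit, with no number of its own. The steps a step that the two limits leave unreadable from compound 1 to compound 2 and a step that the two limits leave unreadable from compound 1 to compound 3, as well as a step that the two limits leave unreadable from compound 2 to compound 3, stay unreadable because of the limit of > 21500 nM in this assay, at which 3 of the 3 values shown sit. Compound 4 `CCOC(=O)c1c(-c2cccc(C(C)=O)c2)[nH]c2cc(OC)ccc2c1=O` differs from compound 1 by acetyl in place of hydrogen on an aromatic carbon. Within the data shown here, no measured step gives a readable size for any change at this position, and all three compounds sit at the limit, so no step beyond the scatter is expected in this assay either way. Compound 4 is therefore estimated to give 30000 nM, in a range of 12000 nM to 90000 nM, most likely again as a limit. The expected step that the limit leaves unreadable from compound 1 to compound 4 is estimated to be no larger than the scatter.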

Compound 4, half-maximal effective concentration: > 21500 nM
Compound 4 was reported as a limit; the forecaster's own chance of this, stated with the estimate: 85%; the middle value does not contradict the limit.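

Among these compounds, no step from compound 1, compound 2 or compound 3 to compound 4 can be read in this assay, as all four stand at the same limit: the limit of > 21500 nM in this assay, at which 4 of the 4 values shown sit. The compounds shown leave open whether any group at this place changes the cytotoxicity at all.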